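Benzyl substituent variation on the shared amide core

A few compounds are considered here, and "the series" means these few. Any claim that something is new, unique, unknown or untested is made for them only; others in the source may bear on it.

Compound 3 `CN(C)c1ccc(CNC(=O)c2nc(Br)c3cccnc3c2N[C@H]2CC[C@H](N)CC2)cc1` carries a 4-(dimethylamino)benzyl amide; in a functional assay on HCT-116 cells (Homo sapiens) for cytotoxicity, read by MTT assay, with a stated time of 72 h (a lower number here means a stronger inhibitor, a higher number a weaker inhibitor), compound 3 is recorded as "not determined" (no result reported), so it stands nowhere on the numbers. Compound 4 `N[C@H]1CC[C@H](Nc2c(C(=O)NCc3ccc(Cl)cc3)nc(Br)c3cccnc23)CC1` differs from it by chloro in place of dimethylamino on an aromatic carbon. Within the data shown here, the one measured step in this part of the series is a 2.0-fold higher number from compound 1 to compound 2 (0.30 log units; within the scatter), between compound 1 `COc1ccc(CNC(=O)c2nc(Br)c3cccnc3c2N[C@H]2CC[C@H](N)CC2)cc1`, which in this assay gives 3000 nM, and compound 2 `N[C@H]1CC[C@H](Nc2c(C(=O)NCc3ccc(Cl)cc3Cl)nc(Br)c3cccnc23)CC1`, which gives 6000 nM. Among the measured compounds shown here, no measured pair bears on the dimethylamino-to-chloro exchange itself; the data show only that two different benzyl substituents sit within the scatter of each other. Because compound 1 gives 3000 nM and compound 2 gives 6000 nM, compound 4 is expected near them, at an estimated 4000 nM with a range of 1500 nM to 12000 nM.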

Compound 4, half-maximal inhibitory concentration: 4000 nM
For compound 4 middle estimate and measured number coincide at the digits printed; the measured number falls inside the stated range.
By their numbers in this assay, from the lowest: compounds 1, 4 and 2 (each within the scatter of the next).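

In this assay, the step with hydrogen in place of chloro reads a 1.5-fold lower number from compound 2 to compound 4 (0.18 log units; within the scatter), and the step with chloro in place of methoxy reads a 1.3-fold higher number from compound 1 to compound 4 (0.12 log units; within the scatter). Both lie within the scatter, so on this aromatic ring neither the extra chloro of compound 2 nor the methoxy-to-chloro exchange separates these compounds. Nothing available bears on the reason for these results. Open, from the compounds shown here alone, is whether a carboxylic acid or a primary amine on that aromatic carbon, or a longer chain in place of the benzyl, would give a number beyond the scatter of compound 1, compound 2 and compound 4.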